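Swapping a benzyl group on a sulfur-linked side chain

The compounds below may be only part of what the source reports. "The series", "measured", "known", "first", "only" and "open" are said of these compounds alone.

Of the compounds shown here, three of one family have been measured in an ADME assay on microsomes from liver (Homo sapiens) for metabolic stability, read by LC-MS, using NADPH, tested at 5 uM; a higher number here means that the compound lasts longer, a lower number that the compound disappears faster. Compound 1, `Cc1ccc(CSc2cc(Cl)c(C)cc2S(=O)(=O)/N=C(\N)n2nc(C)cc2-c2ccccc2)cc1`, gives 0.176 h. Compound 2, `Cc1cc(-c2ccccc2)n(/C(N)=N/S(=O)(=O)c2cc(C)c(Cl)cc2SCc2cccc(C(F)(F)F)c2)n1`, gives 0.169 h. Compound 3, `Cc1cc(S(=O)(=O)/N=C(\N)n2nccc2-c2ccccc2)c(SCc2cccc(C(F)(F)F)c2)cc1Cl`, gives 0.0863 h.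

Two single changes connect these. From compound 2 to compound 1 the change is 4-methylphenyl in place of 3-(trifluoromethyl)phenyl on a saturated chain carbon bound to a sulfur, and the half-life shows a 1.0-fold higher number from compound 2 to compound 1 (0.02 log units; within the scatter). From compound 2 to compound 3 the change is hydrogen in place of methyl on an aromatic carbon, and the half-life shows a 2.0-fold lower number from compound 2 to compound 3 (0.29 log units; within the scatter).

Compound 4, `Cc1ccc(CSc2cc(Cl)c(C)cc2S(=O)(=O)/N=C(\N)n2nccc2-c2ccccc2)cc1`, has not yet been measured in this assay. It differs from compound 3 by 4-methylphenyl in place of 3-(trifluoromethyl)phenyl on a saturated chain carbon bound to a sulfur. For the measured compounds named here, this is the same change as the one from compound 2 to compound 1, made on a core that differs by hydrogen in place of methyl on an aromatic carbon.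

Since that earlier swap left the half-life essentially where it was, the expectation for compound 4 is a step of a 1.0-fold higher number from compound 3 to compound 4 (0.02 log units; within the scatter) from compound 3, resting on the earlier result of a 1.0-fold higher number from compound 2 to compound 1 (0.02 log units; within the scatter). Compound 4 is therefore estimated at 0.09 h in this assay, with a likely range from 0.045 h to 0.18 h. Going by the values given here, only one earlier instance of this swap exists, so this expectation rests on a narrow base.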

Compound 4, half-life: 0.13 h
The estimate for compound 4 lay 1.4-fold (0.16 log units) below the measured number, and the stated range covers the measured number.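

In this assay, putting 4-methylphenyl in place of 3-(trifluoromethyl)phenyl on the core without the methyl gives a 1.5-fold higher number from compound 3 to compound 4 (0.18 log units; within the scatter), and this agrees with the same swap on the core that carries the methyl: the same change on two cores in this assay, a 1.0-fold higher number (0.02 log units; within the scatter) from compound 2 to compound 1 and a 1.5-fold higher number (0.18 log units; within the scatter) from compound 3 to compound 4, 1.4-fold (0.16 log units) apart, within the scatter of two such steps
The other change, hydrogen in place of methyl on an aromatic carbon, gives a 1.4-fold lower number from compound 1 to compound 4 (0.13 log units; within the scatter) when the side chain carries 4-methylphenyl, and it also agrees with its earlier instance: the same change on two cores in this assay, a 2.0-fold lower number (0.29 log units; within the scatter) from compound 2 to compound 3 and a 1.4-fold lower number (0.13 log units; within the scatter) from compound 1 to compound 4, 1.4-fold (0.16 log units) apart, within the scatter of two such steps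
So in these four compounds each change behaves alike on both cores as far as the scatter can tell, but every step lies within that scatter, so this does not show that either change really moves the half-life, nor does a match on just two cores show that the changes would carry over to other members of the series.

The compounds shown leave open what happens when the aromatic ring on the saturated chain carbon bound to a sulfur gives way to a longer chain, or when that ring carries a carboxylic acid. They also leave open whether an ethyl group or an amine in place of the methyl on the aromatic carbon would give a step that stands clear of the scatter.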